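Benzyl Replacements on a Nucleoside Core in K562 Cells

The compounds below may be only part of what the source reports. "The series", "measured", "known", "first", "only" and "open" are said of these compounds alone.

Compound 1 `OC[C@H]1O[C@@H](n2cnc3c(NCc4ccccc4F)ncnc32)[C@H](O)[C@@H]1O` — 33200 nM
Compound 2 `OC[C@H]1O[C@@H](n2cnc3c(NCc4ccc(F)c(F)c4F)ncnc32)[C@H](O)[C@@H]1O` — > 166000 nM

In a functional assay on K562 cells (Homo sapiens) for antiproliferative activity, with a stated time of 72 h (on this read-out higher numbers stand for weaker inhibition and lower numbers for stronger inhibition), compound 1 gives 33200 nM. In this assay compound 2 gives only a limit, > 166000 nM. Compound 2 therefore stands at the weak end of the numbers shown, with no exact value. Going by the values given here, the single measured step, an at least 5.0-fold higher number from compound 1 to compound 2 (0.69 log units; beyond the scatter), is bounded by the limit of > 166000 nM in this assay, at which 1 of the 2 values shown sits, and is known only as a lower bound. Compound 3 `COc1cccc(CNc2ncnc3c2ncn3[C@@H]2O[C@H](CO)[C@@H](O)[C@H]2O)c1O` differs from compound 2 by 2-hydroxy-3-methoxyphenyl in place of 2,3,4-trifluorophenyl on a saturated chain carbon bound to a nitrogen on an aromatic ring. No measured step covers this change; the one step shown concerns the fluorine pattern alone and gives no direct guide here. Compound 3 is expected to return to a measurable number, with an at least 3.3-fold lower number from compound 2 to compound 3 (0.52 log units; beyond the scatter) expected toward stronger inhibition, though with wide uncertainty. Compound 3 is estimated at 50000 nM, between 12000 nM and 166000 nM.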

Compound 3, half-maximal inhibitory concentration: 27900 nM
Compound 3: the middle estimate sits 1.8-fold (0.25 log units) above what was measured; measured number inside the range.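

In this assay, 2-hydroxy-3-methoxyphenyl in place of 2,3,4-trifluorophenyl, on a saturated chain carbon bound to a nitrogen on an aromatic ring, restores a measurable number, with an at least 5.9-fold lower number from compound 2 to compound 3 (0.77 log units; beyond the scatter). The size of that step is only a lower bound, as compound 2 has a limit and not a number: the limit of > 166000 nM in this assay, at which 1 of the 3 values shown sits. Against 2-fluorophenyl, the same group gives a 1.2-fold lower number from compound 1 to compound 3 (0.08 log units; within the scatter), so fluorine on this ring is not needed for a measurable number, and compound 2 alone among the three lacks one.

The compounds shown leave open whether the hydroxy or the methoxy group accounts for the change, as the two enter together. They also do not tell how an amine or a carboxylic acid on this ring, or a longer chain to the nitrogen, would read.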